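A few compounds are considered here, and "the series" means these few. Any claim that something is new, unique, unknown or untested is made for them only; others in the source may bear on it.

Working notes on the series, read in a functional assay on RAW264.7 cells (Mus musculus) for inhibition, read by Griess assay, with a stated time of 24 h; a higher number here means that more compound is needed for the effect, a lower number that less compound is needed. Compound 1 `Oc1cc2c(cc1O)C(c1ccco1)=NCC2` gives 18100 nM, compound 2 `CCOC(=O)CC[C@@H]1NCCc2cc(O)c(O)cc21` gives 36300 nM, and compound 3 `CC1=NCCc2cc(O)c(O)cc21` gives 209000 nM, the highest number of the three.

Compound 4 `Oc1cc2c(cc1O)CCN=C2` has not yet been measured. The change leading to it is hydrogen in place of methyl on a carbon with a double bond to nitrogen, which is hydrogen in place of methyl on a carbon with a double bond to nitrogen.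

Within the data shown here, only one measured step concerns that same carbon: a 12-fold higher number from compound 1 to compound 3 (1.06 log units; beyond the scatter), a large step for methyl in place of furan-2-yl. Compound 2 differs from compound 3 in more than one place, so it offers no direct comparison. Among the measured compounds shown here, a single step is thin ground for a trend, and no measured compound yet shows the effect of hydrogen at this carbon. The present change removes only a methyl, so a step of that size is not assumed. In this assay, no step beyond the scatter is expected, with a slight lean towards a higher number, the direction seen in a 12-fold higher number from compound 1 to compound 3 (1.06 log units; beyond the scatter). The estimated step is a 1.2-fold higher number from compound 3 to compound 4 (0.08 log units; within the scatter). For compound 4 the expected value is 250000 nM, with an estimated range of 80000 nM to 700000 nM.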

Compound 4, half-maximal effective concentration: 248000 nM
For compound 4 the middle estimate is 1.0-fold (0.00 log units) above the measured one; low and high end bracket the measured number.
By their numbers in this assay, from the lowest: compounds 1 and 2 (each within the scatter of the next); then compounds 3 and 4 (each within the scatter of the next).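

In this assay, hydrogen in place of methyl on the carbon with a double bond to nitrogen gives a 1.2-fold higher number from compound 3 to compound 4 (0.07 log units; within the scatter), so the two groups are not told apart at this position. Hydrogen in place of furan-2-yl on the same carbon gives a 14-fold higher number from compound 1 to compound 4 (1.14 log units; beyond the scatter), a large step that matches a 12-fold higher number from compound 1 to compound 3 (1.06 log units; beyond the scatter), so among the three groups compared here at this carbon, only furan-2-yl separates from the others, with the lower number. No measurement shown offers an explanation for these steps.

The compounds shown do not tell whether this separation belongs to furan-2-yl alone or would also appear with another ring or chain at this carbon, such as a phenyl ring or a propyl chain. Compound 2, with its ethyl ester chain, differs from the others in more than one place, so the contribution of that chain cannot be read from these compounds.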